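Oxan-4-yl Out, Methoxy In: Estimating Compound 4

The source may hold more compounds than are shown below. What is called first, only, known or untested is meant among the compounds shown, and "the series" means these compounds.

Of the compounds shown here, three sharing one core have been measured in a physicochemical assay for lipophilicity, at pH 7.4; on this read-out lower numbers stand for lower lipophilicity and higher numbers for higher lipophilicity. Compound 1 `CNC(=O)c1cc(C(=O)NC2CC2)cn(Cc2ccc(F)cc2)c1=O` gives 3.2, compound 3 `CNC(=O)c1cc(C(=O)NC2CC2)cn(Cc2ccccc2F)c1=O` gives 3, and compound 2 `CNC(=O)c1cc(C(=O)NCCC2CCOCC2)cn(Cc2ccccc2)c1=O` gives 3.6, the highest of the three and beyond the scatter from both others. For the measured compounds named here, the only single-point step among them, a number 0.20 log units lower from compound 1 to compound 3 (within the scatter), concerns the fluorophenyl group on the benzylic carbon and does not touch the amide chain. Compound 4 `CNC(=O)c1cc(C(=O)NCCOC)cn(Cc2ccccc2)c1=O` differs from compound 2 by methoxy in place of oxan-4-yl on a saturated chain carbon, two bonds along the chain from an amide-type nitrogen. Going by the values given here, no measured step bears on this change, so the expectation rests on the size of the change alone. Compound 4 is therefore expected to show a downward step, a number 0.90 log units lower from compound 2 to compound 4 (beyond the scatter), and an estimated value of 2.7, within a range from 2.2 to 3.2.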

Compound 4, distribution coefficient: 2.7
For compound 4 middle estimate and measured number coincide at the digits printed; measured number inside the range.
By their numbers in this assay, from the lowest: compounds 4, 3 and 1 (each within the scatter of the next, the first and the last beyond it); then compound 2.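

For the compounds shown here, at this position, on the chain two bonds from an amide-type nitrogen, this assay gives the first single-point step beyond the scatter: methoxy in place of oxan-4-yl yields a number 0.90 log units lower from compound 2 to compound 4 (beyond the scatter). The step comes with the loss of the ring and a smaller group, while the counts of hydrogen-bond donors and acceptors stay the same. Nothing available explains the size of this step.

The compounds shown do not separate the loss of the ring from the reduction in size. From the compounds shown here alone, whether an amine in place of methoxy, or a longer chain ending in methoxy, would fall closer to compound 2 or compound 4 remains open.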